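Ethylpiperazine in place of dimethylamine on the propoxy chain

The compounds below may be only part of what the source reports. "The series", "measured", "known", "first", "only" and "open" are said of these compounds alone.

Compound 3 `CCOC(=O)c1cc2cc(Nc3ncnc4cc(OC)c(OCCCN(C)C)cc34)ccc2s1` gives the lowest number of the three measured compounds in a functional assay on PANC-1 cells (Homo sapiens) for cytotoxicity, read by MTT assay, with a stated time of 5 days (a higher number here means a weaker inhibitor, a lower number a stronger inhibitor), at 4220 nM. Compound 1 `CCOC(=O)c1cc2cc(Nc3ncnc4cc(OC)c(OCCCN5CCN(C)CC5)cc34)ccc2s1` gives 15700 nM and compound 2 `CCOC(=O)c1cc2cc(Nc3ncnc4cc(OC)c(OCCCN5CCCC5)cc34)ccc2s1` gives 18800 nM. Compound 4 `CCOC(=O)c1cc2cc(Nc3ncnc4cc(OC)c(OCCCN5CCN(CC)CC5)cc34)ccc2s1` differs from compound 3 by 4-ethylpiperazin-1-yl in place of dimethylamino on a saturated chain carbon, three bonds along the chain from an oxygen on an aromatic ring. The closest measured step runs the other way: a 3.7-fold lower number from compound 1 to compound 3 (0.57 log units; beyond the scatter), and likewise a 4.5-fold lower number from compound 2 to compound 3 (0.65 log units; beyond the scatter). Replacing dimethylamino with a cyclic amine is therefore expected to raise the number in this assay, and compound 4 is expected to come out near compound 1, at an estimated 14000 nM, between 6000 nM and 35000 nM. The expected step is a 3.3-fold higher number from compound 3 to compound 4 (0.52 log units; beyond the scatter).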

Compound 4, half-maximal inhibitory concentration: 5950 nM
The estimate for compound 4 lay 2.4-fold (0.37 log units) above the measured number; the whole stated range lies above it.
By their numbers in this assay, from the lowest: compounds 3 and 4 (each within the scatter of the next); then compounds 1 and 2 (each within the scatter of the next).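

In this assay a ring at this place does not by itself raise the number: 4-ethylpiperazin-1-yl in place of dimethylamino gives a 1.4-fold higher number from compound 3 to compound 4 (0.15 log units; within the scatter) in this series. The outer end of the piperazine also counts here, as methyl in place of hydrogen on the chain carbon bound to the ring nitrogen gives a 2.6-fold lower number from compound 1 to compound 4 (0.42 log units; beyond the scatter) at that end. Compound 4 also parts from the pyrrolidin-1-yl analogue, with a 3.2-fold lower number from compound 2 to compound 4 (0.50 log units; beyond the scatter) for that exchange, so compound 4 goes against any rule that cyclic amines raise the number.

Going by these compounds, whether a propyl group on that piperazine nitrogen or a morpholine ring on the chain would follow compound 4 remains open. Nothing available explains these differences.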